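Aryl Swap on the Ring Carbon of Compound 3

The source may report more compounds than this note shows. Statements on the series, on what has been measured and on what is new or still open speak of the compounds shown alone.

Compounds measured so far:
- Compound 1 `COc1cc(N2C(N)=C(C#N)C(c3ccc([N+](=O)[O-])cc3)C3=C2CC(C)(C)CC3=O)cc(OC)c1OC`: 10%
- Compound 2 `COc1ccc(C2C(C#N)=C(N)N(c3cc(OC)c(OC)c(OC)c3)C3=C2C(=O)CC(C)(C)C3)cc1`: 0%
- Compound 3 `COc1cc(N2C(N)=C(C#N)C(c3ccccc3O)C3=C2CC(C)(C)CC3=O)cc(OC)c1OC`: 0%

In a functional assay on Ehrlich cells (Mus musculus) for cytotoxicity, tested at 10 ug/mL (on this read-out lower numbers stand for a weaker effect and higher numbers for a stronger effect at the one concentration tested), compound 1 gives 10%, compound 2 gives 0% and compound 3 gives 0%. Compound 3 stands level with compound 2 at the digits reported, and together they are the lowest of the three numbers; the step of a number 10 percentage points lower from compound 1 to compound 3 (within the scatter) is within the scatter.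

Compound 4 `COc1cc(N2C(N)=C(C#N)C(c3ccc(OC)c4ccccc34)C3=C2CC(C)(C)CC3=O)cc(OC)c1OC` differs from compound 3 on a saturated ring carbon: 4-methoxynaphthalen-1-yl in place of 2-hydroxyphenyl on a saturated ring carbon. The measured steps that touch the same position are no change at the digits printed from compound 2 to compound 3 (within the scatter) and a number 10 percentage points lower from compound 1 to compound 3 (within the scatter), and the methoxy-for-nitro swap gave a number 10 percentage points lower from compound 1 to compound 2 (within the scatter). Every change of the aryl group at this carbon has so far stayed inside the scatter, so for compound 4 no step beyond the scatter is expected in this assay, in either direction.

On that basis compound 4 is estimated at 5%, between 0% and 20%, which means an expected step of a number 5 percentage points higher from compound 3 to compound 4 (within the scatter).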

Compound 4, a percentage reported as activity, at one concentration (the size of the read-out at that concentration, not a potency): 10%
For compound 4 the middle estimate is 5 percentage points below the measured one; measured number inside the range.
By their numbers in this assay, from the lowest: compounds 2, 3, 1 and 4 (each within the scatter of the next).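

In this assay the step to a 4-methoxynaphthalen-1-yl group on this saturated ring carbon reads a number 10 percentage points higher from compound 3 to compound 4 (within the scatter) and, against the other two aryl groups, a number 10 percentage points higher from compound 2 to compound 4 (within the scatter) and no change at the digits printed from compound 1 to compound 4 (within the scatter) in turn. Going by these compounds alone, the earlier compounds varied only a single six-membered aromatic ring here, whereas compound 4 shows that 2 six-membered aromatic rings and the loss of the hydrogen-bond donor of the 2-hydroxyphenyl group also leave the read-out within the scatter of the other compounds. No available evidence bears on why this position responds in this way.

All four aryl groups leave open what a saturated chain or a piperidine on this carbon would do. As far as these compounds go, whether an aryl group carrying a carboxylic acid or an amine would produce a step beyond the scatter also remains open.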